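Methyl to chloro on the anilino phenyl of the shared core

The compounds below may be only part of what the source reports. "The series", "measured", "known", "first", "only" and "open" are said of these compounds alone.

Measured so far:
compound 1 `COc1cc(Nc2nnc(Cl)c(Nc3cc(OC)c(OC)c(OC)c3)n2)cc(OC)c1OC` — > 50000 nM, a limit of the assay.
compound 2 `COc1cc(Nc2nc(Nc3ccc4c(ccn4C)c3)nnc2Cl)cc(OC)c1OC` — 42100 nM.
compound 3 `COc1cc(Nc2nc(Nc3ccc(C)cc3)nnc2Cl)cc(OC)c1OC` — 27300 nM.

In a functional assay on ECa-109 cells for inhibition, with ECa-109 cell line (Homo sapiens) as the target, read by MTT assay, with a stated time of 48 h (a lower number here means a stronger inhibitor, a higher number a weaker inhibitor), compound 1 gives only a limit, > 50000 nM. Compound 2 gives 42100 nM, and compound 3 gives 27300 nM, the lowest of the two numbers, with compound 2 within the scatter of it. Among the compounds with values here, the single measured step, a 1.5-fold lower number from compound 2 to compound 3 (0.19 log units; within the scatter), stays within the scatter. Compound 4 `COc1cc(Nc2nc(Nc3ccc(Cl)cc3)nnc2Cl)cc(OC)c1OC` differs from compound 3 by chloro in place of methyl on an aromatic carbon. Within the data shown here, no measured step exchanges one substituent for another on this phenyl; the only step that bears on the aryl group at this position is the one from compound 2 to compound 3, and it stayed within the scatter, so no step beyond the scatter is expected in this assay. Compound 4 is estimated at 25000 nM, range 10000 nM to 60000 nM, an expected step of a 1.1-fold lower number from compound 3 to compound 4 (0.04 log units; within the scatter).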

Compound 4, half-maximal inhibitory concentration: 32600 nM
Estimate against measurement, compound 4: 1.3-fold (0.12 log units) below; the range from low to high includes it.
By their numbers in this assay, from the lowest: compounds 3, 4 and 2 (each within the scatter of the next). At a limit, above all of these: compound 1.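

In this assay, chloro in place of methyl on an aromatic carbon, para to a large group, gives a 1.2-fold higher number from compound 3 to compound 4 (0.08 log units; within the scatter), so the exchange produces no readable change at this position. The second comparison, a 1.3-fold lower number from compound 2 to compound 4 (0.11 log units; within the scatter), also stays within the scatter, so 4-chlorophenyl, 4-methylphenyl and 1-methyl-1H-indol-5-yl on this nitrogen cannot be told apart here. On these data alone, it remains open whether an amine, a carboxylic acid or a longer chain at this place on the phenyl would move the number beyond the scatter. Compound 1 gives only a limit, so its standing against the others also remains open: the limit of > 50000 nM in this assay, at which 1 of the 4 values shown sits.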